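Bromo for chloro on a diaryl ether sulfonylurea

The source may report more compounds than this note shows. Statements on the series, on what has been measured and on what is new or still open speak of the compounds shown alone.

Measured so far:
compound 1 `Cc1ccccc1Oc1ccc(C#N)cc1S(=O)(=O)NC(=O)NC(C)C`: 8680 nM
compound 2 `CC(C)NC(=O)NS(=O)(=O)c1cc(C#N)ccc1Oc1ccc(Cl)cc1`: 9460 nM

Both compounds were tested in a functional assay on HEK293 cells for antagonist activity at thromboxane A2 receptor (Homo sapiens), read by fluorescence and calcium flux; a lower number here means a stronger inhibitor, a higher number a weaker inhibitor. Compound 2 gives 9460 nM, the higher of the two numbers, while compound 1 gives 8680 nM. Within the data shown here, the single step measured so far, a 1.1-fold higher number from compound 1 to compound 2 (0.04 log units; within the scatter), exchanged one ring on the ether oxygen for a different one and left the read-out essentially where it was.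

Compound 3 `CC(C)NC(=O)NS(=O)(=O)c1cc(C#N)ccc1Oc1ccc(Br)cc1` has not yet been measured. It differs from compound 2 in one place only: bromo in place of chloro on an aromatic carbon. This exchange of one halogen for another is a far smaller alteration than the measured step, which replaced a whole substituted ring and still stayed within the scatter. Among the measured compounds shown here, no measured step bears directly on a halogen swap, so the expectation rests on how little the larger change moved the number. In this assay no shift beyond the scatter is expected for compound 3, in either direction. The value expected for compound 3 is 9000 nM, with a range from 4500 nM to 18000 nM. The step this estimate implies, a 1.1-fold lower number from compound 2 to compound 3 (0.02 log units; within the scatter), is expected to lie within the scatter.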

Compound 3, half-maximal inhibitory concentration: 9470 nM
Estimate against measurement, compound 3: 1.1-fold (0.02 log units) below, within the range that was stated.
By their numbers in this assay, from the lowest: compounds 1, 2 and 3 (each within the scatter of the next).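

In this assay, among these compounds, the step of a 1.0-fold higher number from compound 2 to compound 3 (0.00 log units; within the scatter) gives the first direct reading of a halogen exchange on this aromatic carbon, para to a large group: at this place, bromo and chloro cannot be told apart. The second step, a 1.1-fold higher number from compound 1 to compound 3 (0.04 log units; within the scatter), adds another comparison of rings on the ether oxygen, with 4-bromophenyl in place of 2-methylphenyl, and it also stays within the scatter, so the three compounds shown read alike. There is no evidence here that could explain why these exchanges leave the number unmoved.

The compounds shown leave open whether any group on this carbon can move the number beyond the scatter, for instance an amine, a carboxylic acid or a methoxy group in place of the halogen. On these data alone, all three also keep the nitrile and the isopropyl group, so it remains open what a carboxylic acid in place of the nitrile or a longer chain in place of the isopropyl group would do in this assay.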